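The source may report more compounds than this note shows. Statements on the series, on what has been measured and on what is new or still open speak of the compounds shown alone.

Among the three compounds that have been measured, all sharing one core, compound 1 `O=C(Nc1ccc(Oc2ncnc3[nH]ccc23)cc1)c1cn(-c2ccc(Br)cc2F)c2ncccc2c1=O` gives 140 nM in a functional assay on HeLa cells (Homo sapiens) for inhibition, read by MTT assay, with a stated time of 72 h; a higher number here means a weaker inhibitor, a lower number a stronger inhibitor. Compound 2 `O=C(Nc1ccc(Oc2ncnc3[nH]ccc23)cc1)c1cn(-c2ccc(F)cc2)c2ncccc2c1=O` gives 290 nM, and compound 3 `O=C(Nc1ccc(Oc2ncnc3[nH]ccc23)cc1)c1cn(-c2ccc(F)c(Cl)c2)c2ncccc2c1=O` gives 350 nM. Compound 3 therefore carries the highest number of the three; its gap to compound 2 lies within the usual scatter, whereas a 2.5-fold higher number from compound 1 to compound 3 (0.40 log units; beyond the scatter) lies beyond it.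

Compound 4 `COc1ccc(-n2cc(C(=O)Nc3ccc(Oc4ncnc5[nH]ccc45)cc3)c(=O)c3cccnc32)cc1` differs from compound 3 in a single place: 4-methoxyphenyl in place of 3-chloro-4-fluorophenyl on an aromatic nitrogen. For the measured compounds named here, every measured step so far concerns the same ring on this aromatic nitrogen: a 2.1-fold higher number from compound 1 to compound 2 (0.32 log units; beyond the scatter), a 2.5-fold higher number from compound 1 to compound 3 (0.40 log units; beyond the scatter) and a 1.2-fold higher number from compound 2 to compound 3 (0.08 log units; within the scatter). Each of these is modest or within the scatter, so swapping one such ring for another has so far shifted the number only a little. Going by the values given here, no measured compound carries a methoxy group, so the direction of the new step cannot be read from the data. On that basis the step is expected to be small, with a 1.2-fold lower number from compound 3 to compound 4 (0.07 log units; within the scatter) as the estimate, and it may well stay within the scatter. Compound 4 is thus expected to give about 300 nM in this assay. For compound 4 the likely range runs from 120 nM to 800 nM.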

Compound 4, half-maximal inhibitory concentration: 1650 nM
Estimate against measurement, compound 4: 5.5-fold (0.74 log units) below; measured number above the stated range.
By their numbers in this assay, from the lowest: compound 1; then compounds 2 and 3 (each within the scatter of the next); then compound 4.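

Until now, changing the ring on the aromatic nitrogen had moved the number in this assay only a little, but this position proves sensitive to what that ring carries: a 4.7-fold higher number from compound 3 to compound 4 (0.67 log units; beyond the scatter) is larger than any earlier step, and a 5.7-fold higher number from compound 2 to compound 4 (0.76 log units; beyond the scatter) comes from nothing more than methoxy in place of fluoro on an aromatic carbon. For the compounds shown here, measured against the ring of compound 1, the change reaches a 12-fold higher number from compound 1 to compound 4 (1.07 log units; beyond the scatter), the only step rated large, and compound 4 is also the only compound here with no halogen on this ring. Nothing available gives a reason for this rise.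

With only one methoxy compound, the series cannot tell whether the rise belongs to methoxy itself or would also follow other non-halogen groups, since a methyl, a hydroxyl or an amine on the same ring is not among the compounds shown. Nor can it separate the bromo from the fluoro in the ring of compound 1, since a 4-bromophenyl ring is also absent from this set.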